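A diol in place of the amine on the amide

The source may report more compounds than this note shows. Statements on the series, on what has been measured and on what is new or still open speak of the compounds shown alone.

Compound 1 `CCn1c(C(=O)NCCN)ccc1C(CC)(CC)c1ccc(OCCC(O)(CC)CC)c(C)c1` is tested in a functional assay on MCF7 cells (Homo sapiens) for antiproliferative activity, read by MTT assay, with a stated time of 48 h (on this read-out higher numbers stand for weaker inhibition and lower numbers for stronger inhibition), where compound 1 gives 670 nM, the highest of the two numbers recorded. Compound 3 `CCn1c(C(=O)N(C)CC(=O)O)ccc1C(CC)(CC)c1ccc(OCCC(O)(CC)CC)c(C)c1` gives 79 nM, a change of an 8.5-fold lower number from compound 1 to compound 3 (0.93 log units; beyond the scatter). Compound 2 `CCC(C)C(NC(=O)c1ccc(C(CC)(CC)c2ccc(OCCC(O)(CC)CC)c(C)c2)n1CC)C(=O)OC` reaches only the limit of this assay, > 50000 nM. Compound 4 `CCn1c(C(=O)NC(CO)CCO)ccc1C(CC)(CC)c1ccc(OCCC(O)(CC)CC)c(C)c1` differs from compound 1 in one place: 3-hydroxy-1-(hydroxymethyl)propyl in place of 2-aminoethyl on an amide-type nitrogen. Within the data shown here, two measured steps bear on this. A larger group on the same amide nitrogen gave an at least 74-fold higher number from compound 1 to compound 2 (1.87 log units; beyond the scatter), while the small (carboxymethyl)(methyl)amino group gave a gain. The incoming group carries no net charge and is of middle size, so a moderate loss is expected: compound 4 is estimated at 2500 nM, between 600 nM and 12000 nM. The expected step is a 3.7-fold higher number from compound 1 to compound 4 (0.57 log units; beyond the scatter).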

Compound 4, half-maximal inhibitory concentration: 31400 nM
Compound 4: middle estimate off by 13-fold (1.10 log units), on the low side; the measured number lies above the stated range.
By their numbers in this assay, from the lowest: compound 3; then compound 1; then compound 4. At a limit, above all of these: compound 2.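

Among these compounds, the amide nitrogen proves less forgiving than the earlier compounds suggested: a 3-hydroxy-1-(hydroxymethyl)propyl group, with no net charge, still gives a 47-fold higher number from compound 1 to compound 4 (1.67 log units; beyond the scatter). The distance from the best compound shown is wider still, with a 400-fold higher number from compound 3 to compound 4 (2.60 log units; beyond the scatter). The smaller group on the same nitrogen gives an at least 1.5-fold lower number from compound 2 to compound 4 (0.20 log units; that floor lies within the scatter), so no order can be claimed for this pair. Compound 2 gives only a limit, not a number: the limit of > 50000 nM in this assay, at which 1 of the 4 values shown sits.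

On these data alone, what remains open is whether a shorter chain such as 2-hydroxyethyl would hold the number of compound 1. The compounds shown also cannot separate the effect of the hydroxy groups from that of chain length.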